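The source may hold more compounds than are shown below. What is called first, only, known or untested is meant among the compounds shown, and "the series" means these compounds.

Compounds measured so far:
- compound 1 `Cc1ccc(-c2cc(/N=C3/NC(=O)CS3)cs2)cc1`: > 50000 nM (a limit, not a number)
- compound 2 `COc1ccc(/C=C2\S/C(=N\c3csc(-c4ccc(Cl)cc4)c3)NC2=O)cc1`: 3800 nM

Among the measured compounds shown here, in a functional assay on HT-29 cells (Homo sapiens) for cytotoxicity, read by MTT assay, with a stated time of 72 h (a higher number here means a weaker inhibitor, a lower number a stronger inhibitor), compound 2 gives 3800 nM, the only exact number available so far. Compound 1 reaches only a limit in this assay, at > 50000 nM. Compound 2 therefore has no other exact value to be ranked against.

The next compound, compound 3 `O=C1N/C(=N/c2csc(-c3ccc(Cl)cc3)c2)S/C1=C\c1ccc(O)cc1`, keeps the rest of compound 2 but carries 4-hydroxyphenyl in place of 4-methoxyphenyl: hydrogen in place of methyl on an oxygen on an aromatic ring. In other words, hydrogen takes the place of methyl on an oxygen on an aromatic ring, turning methoxy into hydroxy. For the measured compounds named here, no measured pair shows what this change does in this assay, so the expectation rests on compound 2 alone, at 3800 nM. A modest shift toward weaker inhibition is expected, although a result within the usual scatter would fit equally well. The estimated change is a 1.4-fold higher number from compound 2 to compound 3 (0.16 log units; within the scatter). For compound 3 the estimated value is 5500 nM, with an expected range of 1800 nM to 18000 nM.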

Compound 3, half-maximal inhibitory concentration: > 50000 nM
Compound 3 was reported as a limit; the forecaster's own chance of this, stated with the estimate: 10%; middle value at least 9.0-fold (0.95 log units) from the limit.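

In this assay, among the compounds shown here, this is the first change at a single position that can be read, and going from methoxy to hydroxy on the 4-phenyl group gives an at least 13-fold higher number from compound 2 to compound 3 (1.11 log units; beyond the scatter). From the compounds shown here alone, compound 3 gives > 50000 nM, which is a limit and not a number, so the full size of this step remains unknown. For the compounds shown here, the methyl on this oxygen therefore matters in this assay: with hydrogen in its place, the exact reading of compound 2 is lost and the result joins the other limit, leaving compound 2 as the only compound with an exact value: the limit of > 50000 nM in this assay, at which 2 of the 3 values shown sit.

What the compounds shown leave open is whether the oxygen tolerates anything other than methyl, for example ethyl or a longer chain, and whether such a group would keep, improve or lose the activity of compound 2. They also do not show how an amine, a fluorine or a carboxylic acid would behave in place of the methoxy group on the same aromatic ring.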